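The source may report more compounds than this note shows. Statements on the series, on what has been measured and on what is new or still open speak of the compounds shown alone.

Compound 1 `CCNc1cc(-c2ccc(NC(=O)Nc3c(C)cccc3C)cc2C)ccn1` was tested in a functional assay on BT-483 cells (Homo sapiens) for cytotoxicity, read by MTT assay, with a stated time of 24 h; on this read-out higher numbers stand for weaker inhibition and lower numbers for stronger inhibition. In this assay compound 1 reaches only the limit > 30000 nM, not a number. Compound 2 `CCNc1cc(-c2ccc(NC(=O)Nc3ccccc3Cl)cc2C)ccn1` carries the change (2-chlorophenyl in place of 2,6-dimethylphenyl on an amide-type nitrogen). In this assay compound 2 also sits at the limit > 30000 nM. Compound 3 `CCNc1cc(-c2ccc(NC(=O)Nc3c(C)cccc3C)cc2OC)ccn1` differs from compound 1 by methoxy in place of methyl on an aromatic carbon. In this assay compound 3 stands at the limit > 30000 nM. The step that the two limits leave unreadable from compound 1 to compound 2 and the step that the two limits leave unreadable from compound 1 to compound 3 are therefore both unreadable, because the limit of > 30000 nM in this assay, at which 3 of the 3 values shown sit, holds all three values.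

Compound 4 `CCNc1cc(-c2ccc(NC(=O)Nc3ccccc3Cl)cc2OC)ccn1` is not yet measured. Within the data shown here, it differs from compound 3 by 2-chlorophenyl in place of 2,6-dimethylphenyl on an amide-type nitrogen, the same change, at the same place, as the one from compound 1 to compound 2, set this time on the core of compound 3. With every measured neighbour at the limit, he expects compound 4 to give 40000 nM in this assay, a range from 20000 nM to 100000 nM, which means an estimated step that the limit leaves unreadable from compound 3 to compound 4, resting on compound 3 with its limit > 30000 nM and on the unreadable step from compound 1 to compound 2.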

Compound 4, half-maximal inhibitory concentration: > 30000 nM
Compound 4: no number, only a limit; the forecaster's own chance of this, stated with the estimate: 85%; the middle value does not contradict the limit.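

Compound 4 stays at a limit in this assay, so neither its step from compound 3 nor its step from compound 2 can be read, because all the compounds shown share one limit: the limit of > 30000 nM in this assay, at which 4 of the 4 values shown sit.

The compounds shown leave open how large either change is in this assay, or whether it has any effect there at all.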